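A few compounds are considered here, and "the series" means these few. Any claim that something is new, unique, unknown or untested is made for them only; others in the source may bear on it.

Of the compounds shown here, three have been tested in a functional assay on COLO 205 cells (Homo sapiens) for cytotoxicity, read by MTT assay, with a stated time of 24 h; on this read-out higher numbers stand for weaker inhibition and lower numbers for stronger inhibition. Compound 2, `Cc1cc2ccccc2nc1-c1cn(-c2ccc(F)cc2)nn1`, gives only a limit of the assay, > 100 ug/mL, so its place on the scale is not fixed by a number. Compound 1, `CCc1cc2ccccc2nc1-c1cn(-c2ccc(F)cc2)nn1`, likewise gives only a limit, > 100 ug/mL. Compound 3, `CCc1cc2ccccc2nc1-c1cn(CCC(F)(F)C(F)(F)C(F)(F)C(F)(F)C(F)(F)C(F)(F)C(F)(F)C(F)(F)F)nn1`, gives a number in this assay, 95.2 ug/mL. Going by the values given here, the one measured step that differs in a single place, a step that the two limits leave unreadable from compound 1 to compound 2, cannot be read, because the limit of > 100 ug/mL in this assay, at which 2 of the 3 values shown sit, leaves both ends of the step unresolved. Compound 4, `CCCCCc1cc2ccccc2nc1-c1cn(-c2ccc(F)cc2)nn1`, differs from compound 2 by butyl in place of hydrogen on a saturated chain carbon bound to an aromatic carbon. Among the compounds with values here, no measured step bears on this change, and the only one-place step known gives no size at all. The expected step from compound 2 to compound 4 in this assay is therefore a number no higher from compound 2 to compound 4 (the limit leaves the size open), meaning no change beyond the scatter is expected. Compound 4 is estimated at 100 ug/mL, with a range from 40 ug/mL to 300 ug/mL, and it is expected that this assay most likely again returns only a limit.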

Compound 4, half-maximal inhibitory concentration: > 100 ug/mL
Compound 4 ended at the assay's limit; the forecaster's own chance of this, stated with the estimate: 70%; the middle value sits exactly at the limit.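

In this assay compound 4 also gives only a limit, > 100 ug/mL. The steps among compound 1, compound 2 and compound 4 cannot be read, because all three stop at the same limit: the limit of > 100 ug/mL in this assay, at which 3 of the 4 values shown sit. As far as these compounds go, whether going from methyl to pentyl changes cytotoxicity at all remains open.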